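From 4-Fluorophenyl to Thiophen-3-yl on a Shared Core

This account rests on a few compounds, and the source may have more. Where it says the series, first, only, none or still open, it means among the compounds named here.

Compound 1 `COc1ccc(C(=O)/C=C/c2ccc(F)cc2)c2c1C=CC(C)(C)O2` in a functional assay on SW-620 cells (Homo sapiens) for antiproliferative activity, read by MTT assay, with a stated time of 24 h (a lower number here means a stronger inhibitor, a higher number a weaker inhibitor), gives > 10000 nM, which is a limit of the measurement rather than a number.
Compound 2 `COc1ccc(C(=O)/C=C/c2ccc(-c3ccccc3)cc2)c2c1C=CC(C)(C)O2` gives > 10000 nM, again a limit.
Compound 3 `CCN(CC)c1ccc(/C=C/C(=O)c2ccc(OC)c3c2OC(C)(C)C=C3)cc1` gives 670 nM.

Compound 1 thus sits at the limit, and only a limit is known for it. Among the compounds with values here, compound 2 sits at the same limit (the limit of > 10000 nM in this assay, at which 2 of the 3 values shown sit), while compound 3 is the one compound with a real number. The change to compound 4 `COc1ccc(C(=O)/C=C/c2ccsc2)c2c1C=CC(C)(C)O2` is thiophen-3-yl in place of 4-fluorophenyl on a double-bonded chain carbon bound to a double-bonded chain carbon. Within the data shown here, no measured step swaps one aromatic ring for another of a different ring size; the steps that exist all change a substituent on the same six-membered ring. From compound 1 to compound 2 the step is a step that the two limits leave unreadable from compound 1 to compound 2, so it tells nothing about direction. The steps of an at least 14-fold lower number from compound 1 to compound 3 (1.17 log units; beyond the scatter) and an at least 14-fold lower number from compound 2 to compound 3 (1.17 log units; beyond the scatter) show that a diethylamino substituent brings the number down, and those are the only large movements seen. Compound 4 carries no such substituent, and its change is of a different kind. For compound 4 the expected step is a step that the limit leaves unreadable from compound 1 to compound 4, that is, none beyond the scatter in this assay. Compound 4 is therefore expected to remain at the limit, with an estimate of 15000 nM and a range from 3000 nM to 60000 nM.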

Compound 4, half-maximal inhibitory concentration: > 10000 nM
Compound 4 gave a limit, no number (the forecaster's own chance of this, stated with the estimate: 70%); the middle value is on the limit's open side.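

Compound 1 and compound 4 both give only a limit in this assay, so the step between them cannot be read, and the swap of 4-fluorophenyl for thiophen-3-yl has no measurable size: the limit of > 10000 nM in this assay, at which 3 of the 4 values shown sit.

The compounds shown leave open whether thiophen-3-yl and 4-fluorophenyl differ at all in their effect on the shared core.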